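A few compounds are considered here, and "the series" means these few. Any claim that something is new, unique, unknown or untested is made for them only; others in the source may bear on it.

Measured so far in a functional assay on PC-3 cells (Homo sapiens) for antiproliferative activity, read by MTT assay, with a stated time of 48 h; on this read-out lower numbers stand for stronger inhibition and higher numbers for weaker inhibition:
compound 1, `Cc1cnc(Nc2ccc(S(C)(=O)=O)cc2)nc1Nc1nc2ccccc2s1`: > 50000 nM
compound 2, `CS(=O)(=O)c1ccc(Nc2nccc(Nc3nc4ccccc4s3)n2)cc1`: 1710 nM

The value of compound 1 is a limit of the assay and not a number; see (the limit of > 50000 nM in this assay, at which 1 of the 2 values shown sits). Within the data shown here, compound 2 stands as the only number in this assay, the one other value being a limit. Among the measured compounds shown here, the single measured step, an at least 29-fold lower number from compound 1 to compound 2 (1.46 log units; beyond the scatter), removes a methyl from an aromatic carbon and so concerns a different group at a different place from the change considered here.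

Compound 3, `COc1ccc2nc(Nc3ccnc(Nc4ccc(S(C)(=O)=O)cc4)n3)sc2c1`, differs from compound 2 by methoxy in place of hydrogen on an aromatic carbon. For the measured compounds named here, no measured step covers a methoxy at this place, so the measured series gives no direction for the change. The expectation for compound 3 is therefore a step of a 1.0-fold lower number from compound 2 to compound 3 (0.00 log units; within the scatter), within the scatter of this assay. Compound 3 is estimated at 1700 nM, with a range from 500 nM to 6000 nM.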

Compound 3, half-maximal inhibitory concentration: 2700 nM
The estimate for compound 3 lay 1.6-fold (0.20 log units) below the measured number, within the range that was stated.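

In this assay, methoxy in place of hydrogen on the six-membered aromatic ring of carbon only gives a 1.6-fold higher number from compound 2 to compound 3 (0.20 log units; within the scatter). Among these compounds, this is the first reading at this place, and it shows that the fused system carries a methoxy without a change beyond the scatter, whereas the only earlier step, at a different place on the shared core, lay beyond it. No measurement shown bears on why methoxy leaves the number within the scatter here.

Going by these compounds, a single group at a single carbon says little about this ring as a whole, and whether methoxy on another carbon of it would read the same stays open. Also open, on these data alone, is whether an amine, a carboxylic acid or a longer alkoxy chain at this place would move the number beyond the scatter.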